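The source may report more compounds than this note shows. Statements on the series, on what has been measured and on what is new or still open speak of the compounds shown alone.

Measured in an ADME assay on HEK293-A cells (Homo sapiens) for cytotoxicity, read by MTT assay, with a stated time of 48 h; on this read-out higher numbers stand for weaker inhibition and lower numbers for stronger inhibition:
Compound 1 `CN1CCN(C[C@H]2CN(c3ccc(-n4cc(-c5ccccn5)cn4)c(F)c3)C(=O)O2)CC1` gives 70 ug/mL.
Compound 2 `CCN1CCN(C[C@H]2CN(c3ccc(-n4cc(-c5ccccn5)cn4)c(F)c3)C(=O)O2)CC1` gives 99 ug/mL.
Compound 3 `O=C1O[C@@H](CSc2cccs2)CN1c1ccc(-n2cc(-c3ccccn3)cn2)c(F)c1` reaches only a limit of the assay, > 400 ug/mL.

Compound 2 holds the highest of the two numbers, with compound 1 within the scatter of it a 1.4-fold higher number from compound 1 to compound 2 (0.15 log units; within the scatter). For the measured compounds named here, the one value beyond them is the limit (the limit of > 400 ug/mL in this assay, at which 1 of the 3 values shown sits).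

Compound 4 `CCC(=O)NC[C@H]1CN(c2ccc(-n3cc(-c4ccccn4)cn3)c(F)c2)C(=O)O1` differs from compound 2 in one place (propanoylamino in place of 4-ethylpiperazin-1-yl on a saturated chain carbon bound to a saturated ring carbon). Going by the values given here, the steps that bear on it both remove the piperazine: an at least 4.0-fold higher number from compound 2 to compound 3 (0.60 log units; beyond the scatter) and an at least 5.7-fold higher number from compound 1 to compound 3 (0.75 log units; beyond the scatter), each at least modest and upward. Compound 4 is therefore expected to move upward beyond the scatter in this assay, a 2.2-fold higher number from compound 2 to compound 4 (0.35 log units; beyond the scatter), though propanoylamino is not (thiophen-2-yl)sulfanyl, so the size is uncertain. Compound 4 is estimated at 220 ug/mL, between 90 ug/mL and 450 ug/mL.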

Compound 4, half-maximal inhibitory concentration: 389 ug/mL
Compound 4: the middle estimate sits 1.8-fold (0.25 log units) below what was measured, and the stated range covers the measured number.
By their numbers in this assay, from the lowest: compounds 1 and 2 (each within the scatter of the next); then compound 4. At a limit, above all of these: compound 3.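

At this place, on a saturated chain carbon bound to a saturated ring carbon, the upward move is not confined to (thiophen-2-yl)sulfanyl: propanoylamino, which has no ring, gives a measured size for it, a 3.9-fold higher number from compound 2 to compound 4 (0.59 log units; beyond the scatter) and a 5.6-fold higher number from compound 1 to compound 4 (0.74 log units; beyond the scatter), both modest. Both steps replace a piperazine with the open-chain amide. The remaining step, an at least 1.0-fold lower number from compound 3 to compound 4 (0.01 log units; that floor lies within the scatter), cannot be read for its size, since one of its two values stands at a limit: the limit of > 400 ug/mL in this assay, at which 1 of the 4 values shown sits.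

The compounds shown leave open whether the move comes from losing the piperazine ring or from gaining the amide. A morpholine or an open-chain amine on the same carbon would separate the two.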